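The source may report more compounds than this note shows. Statements on the series, on what has been measured and on what is new or still open speak of the compounds shown alone.

Of the compounds shown here, two have been measured in an assay on HEK293 cells for agonist activity at Toll-like receptor 8 (Homo sapiens), read by a luciferase reporter, with a stated time of 6 h (on this read-out lower numbers stand for an effect already at smaller amounts and higher numbers for an effect only at larger amounts of compound), and they share one core. Compound 1 `CCCCNc1nc(N)nc2c1CN(C)CC2` gives 0.03 uM in this assay. Compound 2 `CCCCNc1nc(N)nc2c1CN(Cc1ccc(OC)cc1)CC2` gives 0.08 uM in this assay, the higher of the two numbers; the measured step is a 2.7-fold higher number from compound 1 to compound 2 (0.43 log units; beyond the scatter), a modest change. Compound 3 `CCCCNc1nc(N)nc2c1CN(Cc1ccc(-c3ccccc3)cc1)CC2` has not yet been measured in this assay. It differs from compound 2 by phenyl in place of methoxy on an aromatic carbon. Going by the values given here, the single measured step concerns a different change, a 4-methoxyphenyl group entering on a saturated chain carbon bound to an amine nitrogen in a ring, and it was modest; no measured pair shows what exchanging methoxy for phenyl on the six-membered aromatic ring does here. The step from compound 2 to compound 3 is therefore expected to be small, roughly a 1.3-fold higher number from compound 2 to compound 3 (0.10 log units; within the scatter). Compound 3 is estimated at 0.1 uM, with a range from 0.03 uM to 0.4 uM.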

Compound 3, minimum effective concentration: 0.5 uM
Compound 3: middle estimate off by 5.0-fold (0.70 log units), on the low side; measured number outside the range, above it.
By their numbers in this assay, from the lowest: compound 1; then compound 2; then compound 3.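

In this assay, a 6.3-fold higher number from compound 2 to compound 3 (0.80 log units; beyond the scatter) when phenyl replaces methoxy, so a higher concentration of compound 3 is needed before an effect appears. The earlier step covered the entry of the whole 4-methoxyphenyl group, whereas this one changes only the group on an aromatic carbon of that six-membered ring, para to a large group. That single exchange is enough to move the number beyond the usual scatter, so the group at this position matters to this read-out.

On these data alone, with only methoxy and phenyl compared here, it remains open how other groups at this position, such as an amine, a hydroxyl or a fluorine atom, would behave. Nothing in the available data explains why the number rises with this exchange.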